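Lengthening the carbamoyl chain of compound 1

The source may report more compounds than this note shows. Statements on the series, on what has been measured and on what is new or still open speak of the compounds shown alone.

Measured in an ADME assay on CEM-SS cells (Homo sapiens) for cytotoxicity, read by XTT assay, with a stated time of 6 days; a lower number here means that less compound is tolerated, a higher number that more compound is tolerated:
Compound 1 `CCCC(=O)OCSc1ccccc1C(=O)NCCC(N)=O`: > 100 uM
Compound 2 `CCCC(=O)OCSc1ccc(OC)cc1C(=O)NCCC(N)=O`: > 100 uM

Compound 1 gives > 100 uM, which is a limit and not a number. Its position is therefore known only as the limit of > 100 uM in this assay, at which 2 of the 2 values shown sit.

Compound 3 `CCCC(=O)OCSc1ccccc1C(=O)NCCCC(N)=O` has not yet been measured. It differs from compound 1 in one place: carbamoylmethyl in place of carbamoyl on a saturated chain carbon, two bonds along the chain from an amide-type nitrogen. The new group is carbamoylmethyl in place of carbamoyl on a saturated chain carbon, two bonds along the chain from an amide-type nitrogen.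

Going by the values given here, the only measured step is a step that the two limits leave unreadable from compound 1 to compound 2, with methoxy in place of hydrogen on an aromatic carbon. It is a different change, and it has no readable size. No step beyond the usual scatter is therefore expected in this assay, and no direction can be given. The estimated step is a number no higher from compound 1 to compound 3 (the limit leaves the size open). Compound 3 is expected at 100 uM, within an estimated range of 50 uM to 200 uM.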

Compound 3, half-maximal toxic concentration: 56.6 uM
Estimate against measurement, compound 3: 1.8-fold (0.25 log units) above, within the range that was stated.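

Of the compounds shown, only compound 3 gives a number rather than a limit in this assay, and so carbamoylmethyl in place of carbamoyl on a saturated chain carbon, two bonds along the chain from an amide-type nitrogen, yields the first readable step: an at least 1.7-fold lower number from compound 1 to compound 3 (0.24 log units; that floor lies within the scatter). That size is only a floor, since compound 1 is known only as a limit: the limit of > 100 uM in this assay, at which 2 of the 3 values shown sit. The step from compound 1 to compound 2 cannot be read, so the methoxy change offers no size to set beside this one.

The compounds shown leave open whether a longer chain would carry the number further in the same direction, or whether a carboxylic acid in place of the carbamoyl would change it. They also leave open how methoxy on the aromatic ring would read on the chain of compound 3.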